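This account rests on a few compounds, and the source may have more. Where it says the series, first, only, none or still open, it means among the compounds named here.

Going by the values given here, compound 1 `C=CC(=C)CC[C@@H]1[C@@]2(C)CCC[C@](C)(COC(=O)/C=C\c3ccc(O)cc3)[C@@H]2CC[C@@]1(C)O` is the only member of this small set that gives a numerical reading: in a functional assay on SMMC-7721 cells (Homo sapiens) for cytotoxicity, read by MTT assay, with a stated time of 48 h (a higher number here means a weaker inhibitor, a lower number a stronger inhibitor), compound 1 gives 16200 nM. Compound 2 `C=CC(=C)[C@@H](O)C[C@H]1C(=C)CC[C@@H]2[C@]1(C)CCC[C@]2(C)C(=O)O` reaches only the limit of this assay, giving > 40000 nM, which is a boundary rather than a number. Compound 3 `C=C1CC[C@@H]2[C@](C)(CCC[C@]2(C)C(=O)O)[C@H]1C/C=C(\C)C=O` likewise stops at the limit of this assay, giving > 40000 nM, again not a number. Compound 3 therefore stands at the limit of > 40000 nM in this assay, at which 2 of the 3 values shown sit, and its position relative to compound 2 cannot be read: a step that the two limits leave unreadable from compound 2 to compound 3. Compound 4 `C=C[C@]1(C)O[C@H]1C[C@H]1C(=C)CC[C@@H]2[C@]1(C)CCC[C@]2(C)C(=O)O` has not yet been measured. It differs from compound 3 in one place: a group of 6 heavy atoms (5 carbon, 1 oxygen; one three-membered non-aromatic ring with 1 hetero atom) in place of a group of 5 heavy atoms (4 carbon, 1 oxygen; no ring), on a saturated chain carbon bound to a saturated ring carbon. Among the compounds with values here, the single measured step has limits at both of its ends, so its size cannot be read, and no measured step gives a direction for this change. What remains is the plain observation that compound 3 sits at the limit, and the expectation for compound 4 is that it stays there. The step of a number no higher from compound 3 to compound 4 (the limit leaves the size open) is therefore expected to be nothing beyond the scatter. Compound 4 is accordingly estimated at 40000 nM, within a range from 15000 nM to 100000 nM, with a real chance that this assay once more reports only a limit.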

Compound 4, half-maximal inhibitory concentration: > 40000 nM
Compound 4: a limit, no number (the forecaster's own chance of this, stated with the estimate: 70%); the middle value sits exactly at the limit.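

In this assay compound 4 gives > 40000 nM, a limit and not a number. With limits at both ends, the steps linking compound 2, compound 3 and compound 4 cannot be read. The compounds shown leave open how compound 2, compound 3 and compound 4 would rank if each gave a number.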